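Swapping a piperidine for a sulfone ring on the amine

This account rests on a few compounds, and the source may have more. Where it says the series, first, only, none or still open, it means among the compounds named here.

Of the compounds shown here, two sharing one core have been tested in a functional assay on cells for antagonist activity at C-X-C chemokine receptor type 4 (Homo sapiens), read by fluorescence and calcium flux, with stated times of 25 min and 90 s; on this read-out lower numbers stand for stronger inhibition and higher numbers for weaker inhibition. Compound 1 `O=S1(=O)CCC(CNCCCCN(C[C@H]2Cc3ccccc3CN2)[C@H]2CCCc3cccnc32)CC1` gives 17 nM. For the measured compounds named here, compound 2 `c1ccc2c(c1)CN[C@@H](CN(CCCCNC1CCNCC1)[C@H]1CCCc3cccnc31)C2` gives 63.4 nM, the higher of the two numbers; the only step measured, a 3.7-fold higher number from compound 1 to compound 2 (0.57 log units; beyond the scatter), put piperidin-4-yl in place of (1,1-dioxothian-4-yl)methyl on an amine nitrogen.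

Compound 3 `O=S1(=O)CCC(NCCCCN(C[C@H]2Cc3ccccc3CN2)[C@H]2CCCc3cccnc32)CC1` has not yet been measured. It differs from compound 2 by 1,1-dioxothian-4-yl in place of piperidin-4-yl on an amine nitrogen. Going by the values given here, this change largely undoes the one measured step, bringing back the sulfone-bearing ring of compound 1, though attached directly to the amine nitrogen rather than through the extra chain carbon of (1,1-dioxothian-4-yl)methyl. Since the step from compound 1 to compound 2 was modest but beyond the scatter, reversing most of it is expected to lower the number again in this assay, though the shorter link leaves some uncertainty. Compound 3 is therefore estimated at 25 nM, within 10 nM to 70 nM, an expected step of a 2.5-fold lower number from compound 2 to compound 3 (0.40 log units; beyond the scatter).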

Compound 3, half-maximal inhibitory concentration: 45.5 nM
Compound 3: middle estimate off by 1.8-fold (0.26 log units), on the low side; the range from low to high includes it.
By their numbers in this assay, from the lowest: compound 1; then compounds 3 and 2 (each within the scatter of the next).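

In this assay, a 1.4-fold lower number from compound 2 to compound 3 (0.14 log units; within the scatter), so with the ring attached directly to the amine nitrogen, 1,1-dioxothian-4-yl and piperidin-4-yl cannot be told apart, even though the hydrogen-bond donor of piperidin-4-yl is lost and the sulfone oxygens enter. The sulfone-bearing ring alone therefore does not account for the lower number of compound 1: with that ring kept, shortening (1,1-dioxothian-4-yl)methyl to 1,1-dioxothian-4-yl gives a 2.7-fold higher number from compound 1 to compound 3 (0.43 log units; beyond the scatter), a modest step beyond the scatter. The earlier step from compound 1 to compound 2 changed both the ring and its link at once, and these results place the clearer difference with the methyl link rather than with the ring.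

The data available offer no measurement that explains why this link matters. On these data alone, it remains open whether a piperidin-4-ylmethyl group would show the same gain from the extra carbon, and whether a longer chain such as 2-(1,1-dioxothian-4-yl)ethyl on the amine nitrogen would extend the trend or reverse it.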